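From Methyl to Cyclopropyl on an Ester-Bearing Chain

The source may hold more compounds than are shown below. What is called first, only, known or untested is meant among the compounds shown, and "the series" means these compounds.

Compound 1, `COc1cc(-n2cnn3cc(-c4ccc(Cl)cc4)cc3c2=O)ccc1OCC(C)OC(=O)[C@@H](N)C(C)C`: 2.6%
Compound 2, `COc1cc(-n2cnn3cc(-c4ccc(Cl)cn4)cc3c2=O)ccc1OCC1(OC(=O)CN)CC(F)(F)C1`: 1.6%

In a functional assay on the whole organism (strain Sprague-Dawley) with Rattus norvegicus as the target, with a stated time of 4 days, at a dose of 3 mg/kg by the oral route (on this read-out lower numbers stand for less inhibition and higher numbers for more inhibition at the one dose given (going by the name of the read-out)), compound 1 gives 2.6%. Compound 2 gives 1.6%, a number within the usual scatter of the first, so neither compound stands apart from the other. Compound 3, `COc1cc(-n2cnn3cc(-c4ccc(Cl)cc4)cc3c2=O)ccc1OCC(OC(=O)[C@@H](N)C(C)C)C1CC1`, has not yet been measured. It differs from compound 1 in one place: cyclopropyl in place of methyl on a saturated chain carbon bound to an oxygen next to a carbonyl group and a saturated chain carbon. Among the measured compounds shown here, no measured pair shows what such a change does here. With both known numbers close to the bottom of the scale, the step is expected to stay within the scatter, a number 0.4 percentage points higher from compound 1 to compound 3 (within the scatter). Compound 3 is therefore estimated at 3%, with a range from 0% to 12%.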

Compound 3, a percentage reported as inhibition, in the whole organism at one dose (the size of the read-out at that dose, not a potency): 0%
Estimate against measurement, compound 3: 3 percentage points above; the range from low to high includes it.
By their numbers in this assay, from the lowest: compounds 3, 2 and 1 (each within the scatter of the next).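

Putting cyclopropyl in place of methyl on this saturated chain carbon gives a number 2.6 percentage points lower from compound 1 to compound 3 (within the scatter) in this assay. At this one dose, the swap from one carbon to three therefore cannot be told apart from no change, and this position now has its first measured step. No other measurement bears on this result.

Still open, as far as these compounds go, is whether a longer chain or an amine on this carbon would give a number beyond the scatter. The compounds shown also leave open whether a higher dose would separate compound 1 from compound 3.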